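Swapping the Chain-End Pyrazole for Phenyl

A few compounds are considered here, and "the series" means these few. Any claim that something is new, unique, unknown or untested is made for them only; others in the source may bear on it.

Compound 1 `O=C(NCCCCn1cccn1)c1cccc(C2SCC(=O)N2c2cccnc2)c1`, compound 2 `COc1ccc(F)cc1N1C(=O)CSC1c1cccc(C(=O)NCCCCn2cccn2)c1` and compound 3 `COc1ccccc1N1C(=O)CSC1c1cccc(C(=O)NCCCCn2cccn2)c1` share one core and differ only in the group on the amide-type nitrogen in the ring. In a functional assay on HOS-TE85 cells (Homo sapiens) for inhibition, read by CCK-8 assay, with a stated time of 72 h (on this read-out higher numbers stand for weaker inhibition and lower numbers for stronger inhibition), compound 1 gives only a limit, > 1000 nM. Compound 2 gives 97.3 nM in this assay, and compound 3 gives 91.7 nM, the two numbers lying within the scatter of each other a 1.1-fold lower number from compound 2 to compound 3 (0.03 log units; within the scatter). Both steps away from that limit are large: an at least 10-fold lower number from compound 1 to compound 2 (1.01 log units; beyond the scatter) and an at least 10-fold lower number from compound 1 to compound 3 (1.03 log units; beyond the scatter). Compound 4 `COc1ccc(F)cc1N1C(=O)CSC1c1cccc(C(=O)NCCCCc2ccccc2)c1` differs from compound 2 in one place only: phenyl in place of 1H-pyrazol-1-yl on a saturated chain carbon, four bonds along the chain from an amide-type nitrogen. Among the compounds with values here, no measured step touches that chain carbon, so none bears directly on this change. The expected step is therefore none beyond the scatter, a 1.2-fold higher number from compound 2 to compound 4 (0.09 log units; within the scatter). Compound 4 is expected to give 120 nM, between 40 nM and 400 nM.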

Compound 4, half-maximal inhibitory concentration in the HOS-TE85 assay: 8.8 nM
Compound 4: middle estimate off by 14-fold (1.13 log units), on the high side, and the stated range ends above it.
By their numbers in the HOS-TE85 assay, from the lowest: compound 4; then compounds 3 and 2 (each within the scatter of the next). At a limit, above all of these: compound 1.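

In the HOS-TE85 assay phenyl in place of 1H-pyrazol-1-yl on the saturated chain carbon lowers the number sharply (an 11-fold lower number from compound 2 to compound 4 (1.04 log units; beyond the scatter)). Within the data shown here, the far end of the chain, which no earlier step touched, therefore matters as much in this assay as the group on the ring nitrogen. The same change also moves a second read-out: in a physicochemical assay for solubility, read by turbidimetry, measured as kinetic solubility, at pH 7.4 (on this read-out higher numbers stand for higher solubility and lower numbers for lower solubility), compound 2 gives 50000 nM and compound 4 gives 10000 nM as the lower number.

Still open, from the compounds shown here alone, is whether a pyridine ring, an amine or a shorter chain at this position would keep the low number in the HOS-TE85 assay while giving a higher one in the physicochemical assay as well.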